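From cyano to fluoro in compound 3

A few compounds are considered here, and "the series" means these few. Any claim that something is new, unique, unknown or untested is made for them only; others in the source may bear on it.

Measured compounds:
- Compound 1 `CC(C)OC(=O)C1CN(C(=O)C2CCCCC2)CC(C)(C)c2cc(C#N)[nH]c21`: > 100 ug/mL (a limit of the assay)
- Compound 2 `CC(C)OC(=O)C1CN(C(=O)c2ccc(C#N)cc2)CC(C)(C)c2cc(C#N)[nH]c21`: 21 ug/mL

Among the measured compounds shown here, in a physicochemical assay for solubility, at pH 7.4 (on this read-out higher numbers stand for higher solubility and lower numbers for lower solubility), compound 2 gives 21 ug/mL, the only true number so far. Compound 1 stands at a limit, > 100 ug/mL. Compound 3 `CC(C)OC(=O)C1CN(C(=O)c2ccc(F)cc2)CC(C)(C)c2cc(C#N)[nH]c21` carries fluoro in place of cyano on an aromatic carbon. For the measured compounds named here, the one measured step bearing on this is an at least 4.7-fold lower number from compound 1 to compound 2 (0.67 log units; beyond the scatter), where 4-cyanophenyl replaced cyclohexyl on a carbonyl carbon. The present change keeps that aromatic ring, so a smaller step, within the scatter, is expected. The expected change in this assay is a 1.4-fold higher number from compound 2 to compound 3 (0.15 log units; within the scatter). Compound 3 is estimated at 30 ug/mL, with an expected range of 11 ug/mL to 85 ug/mL.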

Compound 3, solubility: > 100 ug/mL
Compound 3: no number, only a limit; the forecaster's own chance of this, stated with the estimate: 7%; middle value at least 3.3-fold (0.52 log units) away from the limit.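

In this assay the aromatic ring alone does not set the low number, since fluoro in place of cyano on that same ring gives an at least 4.7-fold higher number from compound 2 to compound 3 (0.67 log units; beyond the scatter). The earlier step from cyclohexyl changed the whole ring and could not separate the ring from the cyano group on it. Compound 3 stands at a limit of the assay, > 100 ug/mL.

Going by these compounds, how an amine or a methoxy group at this place would read remains open. The step between compound 1 and compound 3 cannot be read, because both sit at one limit: the limit of > 100 ug/mL in this assay, at which 2 of the 3 values shown sit.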